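The source may report more compounds than this note shows. Statements on the series, on what has been measured and on what is new or still open speak of the compounds shown alone.

Measured in an ADME assay on HCT-116 cells (Homo sapiens) for cytotoxicity, read by CellTiter-Glo, with a stated time of 72 h (on this read-out higher numbers stand for weaker inhibition and lower numbers for stronger inhibition), each value a limit and not a number:
- compound 1 `CC1CCN(C2CCN(S(=O)(=O)c3cccc(N)c3)CC2)CC1`: > 5000 nM
- compound 2 `COc1ccccc1-c1cccc(S(=O)(=O)N2CCC(N3CCC(C)CC3)CC2)c1`: > 5000 nM
- compound 3 `CC1CCN(C2CCN(S(=O)(=O)c3cccc(Cl)c3)CC2)CC1`: > 5000 nM

Compound 3 stands only at its limit of > 5000 nM, and the whole set rests on (the limit of > 5000 nM in this assay, at which 3 of the 3 values shown sit). Compound 4 `CC1CCN(C2CCN(S(=O)(=O)c3cccc(-c4ccccc4C(F)(F)F)c3)CC2)CC1` carries 2-(trifluoromethyl)phenyl in place of chloro on an aromatic carbon. The nearest measured changes are a step that the two limits leave unreadable from compound 2 to compound 3 and a step that the two limits leave unreadable from compound 1 to compound 2, so neither gives a size. Compound 2, with its 2-methoxyphenyl group, still gives only the limit > 5000 nM. No clear step is therefore expected in either direction, and the expected step is a step that the limit leaves unreadable from compound 3 to compound 4. Compound 4 is estimated at 7000 nM, with an expected range from 2500 nM to 20000 nM.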

Compound 4, half-maximal inhibitory concentration: > 5000 nM
Compound 4: only a limit was reported (the forecaster's own chance of this, stated with the estimate: 85%); the middle value is on the limit's open side.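

Compound 4 gives only a limit, > 5000 nM, so its steps from compound 1, compound 2 and compound 3 cannot be read. The compounds shown leave open whether any group on the shared core changes the read-out, since the whole set rests on one limit: the limit of > 5000 nM in this assay, at which 4 of the 4 values shown sit.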